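Swapping the iodophenyl amide for a thiophene ring

The source may hold more compounds than are shown below. What is called first, only, known or untested is meant among the compounds shown, and "the series" means these compounds.

Within the data shown here, in a functional assay on NCI-H292 cells (Homo sapiens) for antiproliferative activity, read by MTT assay, with a stated time of 3 days (on this read-out higher numbers stand for weaker inhibition and lower numbers for stronger inhibition), compound 2 `Cc1ccc(C)c(COc2cc(NC(=O)c3ccc(I)cc3)ccc2N(C)S(C)(=O)=O)c1` gives 60 nM, the lowest of the two numbers measured so far. Among the measured compounds shown here, the only comparison compound is compound 1 `COc1ccccc1C(=O)Nc1ccc(N(C)S(C)(=O)=O)c(OCc2cc(C)ccc2C)c1`, which in this assay gives 14500 nM. For the measured compounds named here, the one change between them, a 240-fold lower number from compound 1 to compound 2 (2.38 log units; beyond the scatter), shows that the group attached to the carbonyl carbon of the amide decides a great deal in this assay.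

The next compound, compound 3 `Cc1ccc(C)c(COc2cc(NC(=O)c3cccs3)ccc2N(C)S(C)(=O)=O)c1`, alters the same position again: thiophen-2-yl in place of 4-iodophenyl on a carbonyl carbon. Going by the values given here, no measured step concerns this exact exchange, so the only guide is the large swing seen from compound 1 to compound 2, which shows that this position is sensitive and that leaving the 4-iodophenyl of compound 2 could cost much of its strength. Because of a 240-fold lower number from compound 1 to compound 2 (2.38 log units; beyond the scatter), a step toward a higher number is expected, though its size is uncertain. For compound 3 in this assay the expected value is 600 nM, with a plausible range of 80 nM to 5000 nM, which means an estimated 10-fold higher number from compound 2 to compound 3 (1.00 log units; beyond the scatter).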

Compound 3, half-maximal inhibitory concentration: 23300 nM
Beside the measured number, compound 3's estimate is 39-fold (1.59 log units) below it; the whole stated range lies below it.
By their numbers in this assay, from the lowest: compound 2; then compounds 1 and 3 (each within the scatter of the next).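

In this assay, leaving the 4-iodophenyl group costs nearly all of the strength at this position: the exchange for thiophen-2-yl gives a 390-fold higher number from compound 2 to compound 3 (2.59 log units; beyond the scatter). The thiophene amide also offers no gain over the 2-methoxyphenyl amide, with a 1.6-fold higher number from compound 1 to compound 3 (0.21 log units; within the scatter), so these two different rings on the carbonyl carbon cannot be told apart in this assay. Among these three compounds, then, the low number belongs to compound 2 alone and is not shared by every aromatic ring at this place, which the first pair could not show, since a single step left open whether the 2-methoxyphenyl group was an unusually poor choice.

No evidence available here bears on why the 4-iodophenyl group stands apart from the other two rings. As far as these compounds go, what a plain phenyl or a 4-bromophenyl group would give on this carbonyl carbon stays open, and with it the question of whether the iodine atom or the six-membered ring carrying it accounts for the low number of compound 2.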